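The source may report more compounds than this note shows. Statements on the series, on what has been measured and on what is new or still open speak of the compounds shown alone.

Measured so far:
compound 1 `C=C1C[C@]23C[C@@]1(O)CC[C@H]2c1ccc(O)c(C)c1[C@@H]3Cn1cc(-c2ccccn2)nn1`; in a functional assay on SW480 cells (Homo sapiens) for cytotoxicity, read by MTT assay, with a stated time of 4 days (on this read-out higher numbers stand for weaker inhibition and lower numbers for stronger inhibition), compound 1 gives > 20000 nM, a limit of the assay.
compound 2 `C=C1C[C@]23C[C@@]1(O)CC[C@H]2c1ccc(OS(=O)(=O)c2ccc(C)cc2)c(C)c1[C@@H]3Cn1cc(-c2ccc(Br)cc2)nn1`; in this assay compound 2 gives > 20000 nM, again a limit.
compound 3 `C=C1C[C@]23C[C@@]1(O)CC[C@H]2c1ccc(O)c(C)c1[C@@H]3Cn1cc(-c2ccc(C(F)(F)F)cc2)nn1`; in this assay compound 3 gives > 20000 nM, also a limit.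

Compound 3 therefore stands only at a limit, and the same holds across the series: the limit of > 20000 nM in this assay, at which 3 of the 3 values shown sit. Among the measured compounds shown here, the one single-place step measured, a step that the two limits leave unreadable from compound 1 to compound 3, cannot be read for size or direction. Compound 4 `C=C1C[C@]23C[C@@]1(O)CC[C@H]2c1ccc(O)c(C)c1[C@@H]3Cn1cc(-c2ccc(Br)cc2)nn1` differs from compound 3 by bromo in place of trifluoromethyl on an aromatic carbon. For the measured compounds named here, no measured step bears on this change, and with every value at the limit nothing beyond the scatter can be expected in this assay; the estimated step is a step that the limit leaves unreadable from compound 3 to compound 4. Compound 4 is thus expected at 30000 nM, with a range from 12000 nM to 80000 nM, most probably again reported only as a limit.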

Compound 4, half-maximal inhibitory concentration: > 20000 nM
Compound 4 was reported as a limit (the forecaster's own chance of this, stated with the estimate: 85%); the middle value lies beyond the limit too.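

The steps to compound 4 from compound 1, compound 2 and compound 3 cannot be read, as all four compounds sit at a limit: the limit of > 20000 nM in this assay, at which 4 of the 4 values shown sit.

The compounds shown leave open which change to the shared core, if any, would give a measurable value in this assay.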